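Isobutoxy for dimethylamino: cytotoxicity at the limit

This account rests on a few compounds, and the source may have more. Where it says the series, first, only, none or still open, it means among the compounds named here.

Compound 3 `CCOC(=O)CCCCCOc1cccc(CN(C(=O)c2ccc(-c3cccc(N(C)C)c3)cc2)C(C)C)c1` is the ethyl-bearing member of the series. In an ADME assay on BJ cells (Homo sapiens) for cytotoxicity, read by CellTiter-Glo and resazurin assay, with a stated time of 72 h (a lower number here means that less compound is needed, a higher number that more compound is needed for the effect), compound 3 gives > 26000 nM, which is a limit of the assay and not a number. The two neighbours stand no differently. Compound 1 `CC(C)N(Cc1cccc(OCCCCCC(=O)O)c1)C(=O)c1ccc(-c2cccc(N(C)C)c2)cc1` gives in this assay the value > 26000 nM, again a limit. Compound 2 `CC(C)Oc1cccc(-c2ccc(C(=O)N(Cc3cccc(OCCCCCC(=O)O)c3)C(C)C)cc2)c1` gives in this assay the value > 26000 nM, also a limit. All three values therefore sit together at the limit of > 26000 nM in this assay, at which 3 of the 3 values shown sit, and nothing within the series is readable as a step.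

The change to compound 4 `CCOC(=O)CCCCCOc1cccc(CN(C(=O)c2ccc(-c3cccc(OCC(C)C)c3)cc2)C(C)C)c1` is isobutoxy in place of dimethylamino on an aromatic carbon. For the measured compounds named here, two measured steps bear on it. The closest analogy is a step that the two limits leave unreadable from compound 1 to compound 2, the same kind of exchange of the dimethylamino for an alkoxy group. The other is a step that the two limits leave unreadable from compound 1 to compound 3, which ties compound 3 to the acid pair. Both are unreadable, since both of their ends are limits, so neither a size nor a direction can be taken from them; there is also nothing that would suggest a departure from the limit.

The step of a number no higher from compound 3 to compound 4 (the limit leaves the size open) is accordingly expected to be nothing readable. Compound 4 is expected at 26000 nM, within 15000 nM to 26000 nM, most probably reported again only as a limit.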

Compound 4, half-maximal effective concentration: > 26000 nM
Compound 4 gave a limit, no number; the forecaster's own chance of this, stated with the estimate: 90%; the middle value sits exactly at the limit.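

Compound 3 and compound 4 both give a limit and not a number in this assay, so the exchange of dimethylamino for isobutoxy between them cannot be read as a step. What stays open is the concentration at which any of the four compounds would show a half-maximal cytotoxic effect: the limit of > 26000 nM in this assay, at which 4 of the 4 values shown sit.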